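Replacing 2-Fluorophenyl with a Hydroxy-Methylethyl Phenyl Group

A few compounds are considered here, and "the series" means these few. Any claim that something is new, unique, unknown or untested is made for them only; others in the source may bear on it.

Measured compounds in a functional assay on MV4-11 cells (Homo sapiens) for antiproliferative activity, read by CCK-8 assay, with a stated time of 72 h; on this read-out lower numbers stand for stronger inhibition and higher numbers for weaker inhibition:
- compound 1 `COc1cccc(-c2cn(C)c(=O)c3[nH]c(C(=O)NCc4ccc(C(=O)Nc5ccccc5N)cc4)cc23)c1`: 250 nM
- compound 2 `Cn1cc(-c2cc(C(C)(C)O)ccc2OC2CC2)c2cc(C(=O)NCc3ccc(C(=O)Nc4ccccc4N)cc3)[nH]c2c1=O`: 40 nM
- compound 3 `Cn1cc(-c2ccccc2F)c2cc(C(=O)NCc3ccc(C(=O)Nc4ccccc4N)cc3)[nH]c2c1=O`: 230 nM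

Compound 3 stands second highest of the three numbers in this assay. Its nearest neighbour is compound 1, which gives a number only slightly higher, within the scatter; compound 2 lies furthest away, with a markedly lower number, beyond the scatter.

Compound 4 `Cn1cc(-c2cccc(C(C)(C)O)c2)c2cc(C(=O)NCc3ccc(C(=O)Nc4ccccc4N)cc3)[nH]c2c1=O` is not yet measured. It differs from compound 3 in one place: 3-(1-hydroxy-1-methylethyl)phenyl in place of 2-fluorophenyl on an aromatic carbon.

Going by the values given here, only one measured step bears on this change: a 1.1-fold lower number from compound 1 to compound 3 (0.04 log units; within the scatter), a swap between two small aryl substituents that left the number essentially unchanged. Among the compounds with values here, no measured step isolates the 3-(1-hydroxy-1-methylethyl)phenyl group alone. Compound 2 carries that group together with a cyclopropoxy group and gives the lowest number of the three, while compound 3 gives a clearly higher one.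

Given this, compound 4 is expected to land between compound 3 and compound 2, with a modest lowering of the number, a 2.3-fold lower number from compound 3 to compound 4 (0.36 log units; beyond the scatter), and an estimated value of 100 nM within a range from 40 nM to 250 nM.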

Compound 4, half-maximal inhibitory concentration: 2200 nM
Estimate against measurement, compound 4: 22-fold (1.34 log units) below; measured number outside the range, above it.
By their numbers in this assay, from the lowest: compound 2; then compounds 3 and 1 (each within the scatter of the next); then compound 4.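

In this assay the 3-(1-hydroxy-1-methylethyl)phenyl group does not lower the number by itself: in place of 2-fluorophenyl it gives a 9.6-fold higher number from compound 3 to compound 4 (0.98 log units; beyond the scatter) and, with 1-hydroxy-1-methylethyl in place of methoxy, the change gives an 8.8-fold higher number from compound 1 to compound 4 (0.94 log units; beyond the scatter) as well. The largest change comes from a different group, since hydrogen in place of cyclopropyloxy gives a 55-fold higher number from compound 2 to compound 4 (1.74 log units; beyond the scatter), so within this pair the cyclopropyloxy group is what separates a low number from a high one. No measurement here explains why these changes raise the number.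

The compounds shown leave open whether cyclopropyloxy would also lower the number alongside a different substituent on that phenyl ring. They also leave open how an amine or a carboxylic acid would compare with 1-hydroxy-1-methylethyl.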